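A Methoxy Group Added to Compound 3

This account rests on a few compounds, and the source may have more. Where it says the series, first, only, none or still open, it means among the compounds named here.

For the measured compounds named here, in a functional assay on MCF7 cells (Homo sapiens) for inhibition, read by colorimetric assay and MTT assay, with a stated time of 72 h (a higher number here means a weaker inhibitor, a lower number a stronger inhibitor), compound 3 (`C=CCCCCOc1ccccc1-c1cnc(OCCC=C)n1C`) gives 8000 nM, the lowest of the three numbers measured so far. Compound 2 (`Cn1c2cnc1OCCCCCCCCCCOc1ccccc1-2`) gives 24000 nM and compound 1 (`COc1ccc2c(c1)-c1cnc(n1C)OCCCCCCCCO2`) gives 32000 nM. Both of these numbers lie beyond the scatter from compound 3.

Compound 4 (`C=CCCCCOc1ccc(OC)cc1-c1cnc(OCCC=C)n1C`) differs from compound 3 in one place, with methoxy in place of hydrogen on an aromatic carbon, para to a (hex-5-en-1-yl)oxy group: methoxy in place of hydrogen on an aromatic carbon. Going by the values given here, no measured pair of compounds isolates this change, so its size in this assay has to be judged with little support. Compound 1 also carries a methoxy group and gives 32000 nM, but it differs from compound 3 in more than that one place, so it offers only a weak hint towards a higher number. The expected step, a 1.1-fold higher number from compound 3 to compound 4 (0.05 log units; within the scatter), is therefore small and not beyond the scatter. The estimated value for compound 4 is 9000 nM, with an expected range of 3500 nM to 24000 nM.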

Compound 4, half-maximal inhibitory concentration: 37000 nM
Beside the measured number, compound 4's estimate is 4.1-fold (0.61 log units) below it; the whole stated range lies below it.
By their numbers in this assay, from the lowest: compound 3; then compounds 2, 1 and 4 (each within the scatter of the next).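

In this assay, for the compounds shown here, this pair isolates the change for the first time, and the step is a 4.6-fold higher number from compound 3 to compound 4 (0.67 log units; beyond the scatter) in the direction of a weaker inhibitor. Methoxy in place of hydrogen at this aromatic carbon, para to a (hex-5-en-1-yl)oxy group, is therefore not a neutral change in this open-chain compound, as the step lies beyond the scatter. Nothing available explains why the number moves in this way.

As far as these compounds go, whether the step belongs to methoxy itself or would follow any group at this carbon remains open, and a fluorine atom, a methyl group or a hydroxyl group there would help to separate the two. From the compounds shown here alone, it also remains open whether methoxy at this position would give a similar step in compound 2, whose two chains are joined.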